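This account rests on a few compounds, and the source may have more. Where it says the series, first, only, none or still open, it means among the compounds named here.

Three compounds share one core and differ only in the aryl group on it. Compound 1 `N#Cc1c(-c2ccccc2O)c(C#N)c(=O)n(/N=C/c2cn(-c3ccccc3)nc2-c2ccccc2)c1N` carries a 2-hydroxyphenyl there, and in an ADME assay on NIH3T3 cells (Mus musculus) for cytotoxicity, read by MTT assay (on this read-out higher numbers stand for weaker inhibition and lower numbers for stronger inhibition), compound 1 gives 162 ug/mL. Compound 2 `N#Cc1c(-c2ccc(O)cc2)c(C#N)c(=O)n(/N=C/c2cn(-c3ccccc3)nc2-c2ccccc2)c1N` carries a 4-hydroxyphenyl, and in this assay compound 2 gives 110 ug/mL. Compound 3 `COc1ccc(-c2c(C#N)c(N)n(/N=C/c3cn(-c4ccccc4)nc3-c3ccccc3)c(=O)c2C#N)cc1` carries a 4-methoxyphenyl, and in this assay compound 3 gives 50 ug/mL, the lowest of the three numbers. The move from 2-hydroxyphenyl to 4-methoxyphenyl was a 3.2-fold lower number from compound 1 to compound 3 (0.51 log units; beyond the scatter), the move from 4-hydroxyphenyl to 4-methoxyphenyl was a 2.2-fold lower number from compound 2 to compound 3 (0.34 log units; beyond the scatter), while the move between the two hydroxyphenyl isomers was a 1.5-fold lower number from compound 1 to compound 2 (0.17 log units; within the scatter).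

Compound 4 `N#Cc1c(-c2ccccc2[N+](=O)[O-])c(C#N)c(=O)n(/N=C/c2cn(-c3ccccc3)nc2-c2ccccc2)c1N` is the next step: 2-nitrophenyl in place of 4-methoxyphenyl on an aromatic carbon. Going by the values given here, no measured compound carries a nitro group, so the measured steps give only loose guidance; the closest comparison is compound 1, whose 2-hydroxyphenyl sits at the same place and gave the highest number. A modest rise in this assay is therefore expected, a 2.0-fold higher number from compound 3 to compound 4 (0.30 log units; within the scatter), and compound 4 is estimated at 100 ug/mL, with a range from 40 ug/mL to 250 ug/mL.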

Compound 4, half-maximal inhibitory concentration: > 200 ug/mL
Compound 4 gave a limit, no number (the forecaster's own chance of this, stated with the estimate: 5%); middle value at least 2.0-fold (0.30 log units) away from the limit.
By their numbers in this assay, from the lowest: compound 3; then compounds 2 and 1 (each within the scatter of the next). At a limit, above all of these: compound 4.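

Compound 4 gives a limit in this assay, not a number: the limit of > 200 ug/mL in this assay, at which 1 of the 4 values shown sits.

Replacing the 4-methoxyphenyl group at this place, opposite the ring nitrogen, gives an at least 4.0-fold higher number from compound 3 to compound 4 (0.60 log units; beyond the scatter), a wider gap than any step among the first three compounds, so this position can carry a change of this size when a nitro-bearing aryl group enters. Against the two hydroxyphenyl compounds, the result is less clear, with an at least 1.8-fold higher number from compound 2 to compound 4 (0.25 log units; that floor lies within the scatter) and an at least 1.2-fold higher number from compound 1 to compound 4 (0.09 log units; that floor lies within the scatter), so these two comparisons set no order among the compounds.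

Going by these compounds, the real number behind the limit for compound 4 remains unknown, so the size of the swap from hydroxy to nitro cannot be stated. On these data alone, it also remains open how an amine or a carboxylic acid on the same phenyl ring would read in this assay.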